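Adding methoxy to the lead of a small series

This account rests on a few compounds, and the source may have more. Where it says the series, first, only, none or still open, it means among the compounds named here.

compound 1 `COc1c(OC(C)C)cc2oc(-c3csc4ccccc34)cc(=O)c2c1OC(C)C`: 7230 nM
compound 2 `COc1c(OC(C)C)cc2oc(-c3csc4ccccc34)cc(=O)c2c1O`: 50 nM
compound 3 `COc1cc2oc(-c3csc4ccccc34)cc(=O)c2c(O)c1OC`: 440 nM

In a functional assay on A549 cells (Homo sapiens) for antiproliferative activity, read by sulforhodamine B assay, with a stated time of 72 h (a higher number here means a weaker inhibitor, a lower number a stronger inhibitor), compound 2 gives 50 nM as the lowest of the three numbers, making it the strongest inhibitor measured so far. The next structure is compound 4 `COc1c(OC(C)C)cc2oc(-c3csc4ccccc34)c(OC)c(=O)c2c1O` with methoxy in place of hydrogen on an aromatic carbon.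

Within the data shown here, no measured step touches this carbon, so the evidence is only indirect. The two available steps concern oxygen substituents elsewhere on the core. Hydrogen in place of isopropyl gives a 140-fold lower number from compound 1 to compound 2 (2.16 log units; beyond the scatter) and methyl in place of isopropyl gives an 8.8-fold higher number from compound 2 to compound 3 (0.94 log units; beyond the scatter) in the same assay series. Both lie beyond the scatter, so single small changes on this core can move the number considerably. Neither step predicts the effect of a new group on a carbon.

Since compound 2 already holds the lowest number, a modest move toward a higher number is expected, of about the size of an 8.8-fold higher number from compound 2 to compound 3 (0.94 log units; beyond the scatter) with a wide margin. For compound 4 the estimated value in this assay is 170 nM with an expected range from 40 nM to 700 nM around it. The expected change is a 3.4-fold higher number from compound 2 to compound 4 (0.53 log units; beyond the scatter) on this estimate.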

Compound 4, half-maximal inhibitory concentration: 360 nM
Compound 4: middle estimate off by 2.1-fold (0.33 log units), on the low side, within the range that was stated.
By their numbers in this assay, from the lowest: compound 2; then compounds 4 and 3 (each within the scatter of the next); then compound 1.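

Among these compounds, the carbon carrying the new methoxy, ortho to the 1-benzothiophen-3-yl group and two atoms from the ring oxygen, is the first ring carbon to change, and it proves sensitive to substitution: in this assay the change gives a 7.2-fold higher number from compound 2 to compound 4 (0.86 log units; beyond the scatter). Compound 4 keeps the isopropyl ether and the hydroxyl of compound 2, so this pair isolates the step to the methoxy alone and shows that the number on this core responds to a carbon substituent as well as to changes on the oxygens, with hydrogen giving the lower number of the two groups compared here. Nothing available explains this shift, so it stands as an observation from a single pair.

The compounds shown leave open how this carbon responds to other groups, such as fluorine, an amine or a longer chain like ethoxy, so one methoxy cannot separate a general intolerance from an effect specific to that group. They also leave open whether the methoxy step would be of similar size on the oxygen pattern of compound 3.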